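Metabolic stability notes: compound 1 to compound 4

This account rests on a few compounds, and the source may have more. Where it says the series, first, only, none or still open, it means among the compounds named here.

Measured so far:
- Compound 1 `Nc1nc(NCCNc2ncc(-c3ncc[nH]3)c(-c3ccc(C(F)(F)F)cc3)n2)ccc1[N+](=O)[O-]`: > 0.5 h in an ADME assay on microsomes from liver (Canis lupus familiaris) for metabolic stability (on this read-out higher numbers stand for a longer-lived compound and lower numbers for a shorter-lived compound), a limit of the assay
- Compound 2 `Nc1nc(NCCNc2ncc(-c3ncc[nH]3)c(-c3ccc(F)cc3F)n2)ccc1[N+](=O)[O-]`: > 0.5 h in this assay, a limit of the assay
- Compound 3 `Cc1ccc(-c2nc(NCCNc3ccc([N+](=O)[O-])c(N)n3)ncc2-c2ncc[nH]2)c(Br)c1`: > 0.5 h in this assay, a limit of the assay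

Compound 1 stands at the limit only; no number is known for it. The same holds for compound 2 and for compound 3, as summed up in the limit of > 0.5 h in this assay, at which 3 of the 3 values shown sit. The steps among the measured compounds are therefore all unreadable: a step that the two limits leave unreadable from compound 1 to compound 2, a step that the two limits leave unreadable from compound 1 to compound 3 and a step that the two limits leave unreadable from compound 2 to compound 3.

Compound 4 `Cc1cc(Cl)ccc1-c1nc(NCCNc2ccc([N+](=O)[O-])c(N)n2)ncc1-c1ncc[nH]1` is not yet measured. It differs from compound 1 in one place: 4-chloro-2-methylphenyl in place of 4-(trifluoromethyl)phenyl on an aromatic carbon. Among the compounds with values here, the steps that bear on this change are those that replace the aryl group on the same carbon of the shared core, from compound 1 to compound 2 and from compound 1 to compound 3, and neither of them gives a readable size.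

With every measured value sitting at the limit, no step beyond the scatter can be read in either direction, and compound 4 is expected to behave like compound 1, with an estimated step that the limit leaves unreadable from compound 1 to compound 4. The expected half-life of compound 4 in this assay is 1 h, with a range from 0.5 h to 3 h, and most probably the assay will again report only the limit.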

Compound 4, half-life: > 0.5 h
Compound 4 gave a limit, no number (the forecaster's own chance of this, stated with the estimate: 85%); the middle value does not contradict the limit.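

Compound 4 joins compound 1, compound 2 and compound 3 in giving only a limit and no number in this assay, so none of the steps from compound 1, compound 2 or compound 3 to compound 4 can be read: the limit of > 0.5 h in this assay, at which 4 of the 4 values shown sit.

The compounds shown leave open whether changing the aryl group on the shared core alters the half-life in this assay at all.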